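The source may hold more compounds than are shown below. What is called first, only, known or untested is meant among the compounds shown, and "the series" means these compounds.

Compound 1 `Cc1ccccc1-n1cc(-c2ccc(/C=C3\C(=O)Nc4ccccc43)cc2)nn1`: in a functional assay on HT-29 cells (Homo sapiens) for inhibition, read by CCK-8 assay, with a stated time of 24 h (a higher number here means a weaker inhibitor, a lower number a stronger inhibitor), compound 1 gives 8710 nM.
Compound 2 `O=C1Nc2ccccc2/C1=C/c1ccc(-c2cn(-c3ccccc3F)nn2)cc1`: in this assay compound 2 gives 10500 nM.

Compound 2 and compound 1 lie within the scatter of each other, as a 1.2-fold higher number from compound 1 to compound 2 (0.08 log units; within the scatter) shows; no ranking between them follows. Compound 3 `O=C1Nc2ccccc2/C1=C/c1ccc(-c2cn(-c3ccc(F)cc3)nn2)cc1` differs from compound 2 by 4-fluorophenyl in place of 2-fluorophenyl on an aromatic nitrogen. Among the compounds with values here, the one measured step, fluoro in place of methyl on an aromatic carbon, exchanges one group for another at the same place and was small; it does not test a shift of the fluorine around the ring. Nothing here points either way, so the expected step is a 1.1-fold lower number from compound 2 to compound 3 (0.02 log units; within the scatter), none beyond the scatter. Compound 3 is estimated at 10000 nM, range 4000 nM to 25000 nM.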

Compound 3, half-maximal inhibitory concentration: 17700 nM
For compound 3 the middle estimate is 1.8-fold (0.25 log units) below the measured one; low and high end bracket the measured number.
By their numbers in this assay, from the lowest: compounds 1, 2 and 3 (each within the scatter of the next, the first and the last beyond it).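

Shifting the fluorine, with 4-fluorophenyl in place of 2-fluorophenyl on the aromatic nitrogen, gives a 1.7-fold higher number from compound 2 to compound 3 (0.23 log units; within the scatter) in this assay and so does not separate the two compounds. Only the wider exchange of 2-methylphenyl for 4-fluorophenyl at this nitrogen passes the scatter, with a 2.0-fold higher number from compound 1 to compound 3 (0.31 log units; beyond the scatter) as a modest step. No measurement on hand offers an explanation for either step.
Still open, as far as these compounds go, is whether 4-methylphenyl would track with compound 1 or compound 3. Also open, from the compounds shown here alone, is whether an amine or a carboxylic acid on this phenyl would give a larger step.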